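The compounds below may be only part of what the source reports. "The series", "measured", "known", "first", "only" and "open" are said of these compounds alone.

Measured so far:
compound 1 `NS(=O)(=O)c1ccc(S(=O)(=O)Nc2cccc3c(Cl)c[nH]c23)cn1`: 290 nM
compound 2 `O=S(=O)(Nc1cccc2c(Cl)c[nH]c12)c1cccnc1`: 260 nM

In a functional assay on HCT-116 cells (Homo sapiens) for inhibition, with a stated time of 72 h (a higher number here means a weaker inhibitor, a lower number a stronger inhibitor), compound 1 gives 290 nM and compound 2 gives 260 nM, the step being a 1.1-fold lower number from compound 1 to compound 2 (0.05 log units; within the scatter). Compound 2 thus carries the lowest number of the two, although its gap to compound 1 is within the scatter. Compound 3 `N#Cc1c[nH]c2c(NS(=O)(=O)c3cccnc3)cccc12` differs from compound 2 by cyano in place of chloro on an aromatic carbon. Among the measured compounds shown here, the single measured step concerns the sulfamoyl, not the chloro, so it does not bear on this change; no measured step gives its size. The working expectation is no step beyond the scatter, a 1.2-fold higher number from compound 2 to compound 3 (0.06 log units; within the scatter). Compound 3 is accordingly estimated at 300 nM, with a range from 100 nM to 900 nM.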

Compound 3, half-maximal inhibitory concentration: 230 nM
Beside the measured number, compound 3's estimate is 1.3-fold (0.12 log units) above it; measured number inside the range.
By their numbers in this assay, from the lowest: compounds 3, 2 and 1 (each within the scatter of the next).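

At the aromatic carbon two ring bonds from the ring nitrogen, cyano in place of chloro gives a 1.1-fold lower number from compound 2 to compound 3 (0.05 log units; within the scatter) in this assay. For this pair, then, the exchange of one chlorine for the two heavy atoms of cyano, which adds a hydrogen-bond acceptor, leaves the number within the scatter. Nothing available explains this result.

Going by these compounds, whether an amine, a carboxylic acid or a longer chain at this carbon would give a similar number remains open. Also open, on these data alone, is whether the cyano change behaves the same way with the sulfamoyl of compound 1 present.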